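Enantiomer pair on the shared core: compound 2 to compound 4

This account rests on a few compounds, and the source may have more. Where it says the series, first, only, none or still open, it means among the compounds named here.

Three compounds of this series have a number in an in vitro functional assay on SH-EP1 cells for agonist activity at Neuronal acetylcholine receptor; alpha4/beta2 (Homo sapiens), read by FLIPR and calcium flux; a lower number here means that less compound is needed, a higher number that more compound is needed for the effect. Compound 1 `COc1cncc(C2=CC3CC(C2)CN(C)C3)c1` gives 5130 nM. Compound 2 `CN1C[C@H]2C=C(c3cccnc3)C[C@H](C2)C1` gives 7660 nM, the highest of the three numbers, though its gap to compound 1 lies within the scatter, so no order between the two can be claimed. Compound 3 `Clc1ccc(C2=CC3CNCC(C2)C3)nn1` gives 595 nM, and the gap between compound 3 and compound 2 lies beyond the scatter.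

Compound 4 `CN1C[C@@H]2C=C(c3cccnc3)C[C@@H](C2)C1` is not yet measured. Its relation to compound 2 is the two compounds have the same atoms and bonds and differ only in configuration as drawn: 2 of 2 stereo elements differ (all stereocentres are inverted: mirror images); a stereocentre at a saturated ring carbon is drawn R in compound 2 and S in compound 4; a stereocentre at a saturated ring carbon is drawn S in compound 2 and R in compound 4. Compound 1 and compound 3 are drawn without configuration, so nothing in the measured set shows what inverting both stereocentres on this core does to the number in this assay. The step from compound 2 to compound 4 could therefore run either way, and the range must stay broad. With compound 2 already at the high end of the set, the expectation leans slightly toward a lower number for compound 4, but the central estimate stays close to compound 2, with the expected step of a 1.9-fold lower number from compound 2 to compound 4 (0.28 log units; within the scatter) not clearly beyond the scatter. Compound 4 is expected to give about 4000 nM in this assay, within 800 nM to 20000 nM.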

Compound 4, half-maximal effective concentration: > 10000 nM
Compound 4 ended at the assay's limit (the forecaster's own chance of this, stated with the estimate: 10%); middle value at least 2.5-fold (0.39 log units) from the limit.
By their numbers in this assay, from the lowest: compound 3; then compounds 1 and 2 (each within the scatter of the next). At a limit, above all of these: compound 4.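

In this assay compound 4 gives > 10000 nM, which is a limit of the assay and not a number. This pair gives the first direct read of configuration on the shared core, with an at least 1.3-fold higher number from compound 2 to compound 4 (0.11 log units; that floor lies within the scatter), so inverting both stereocentres gives no lower number here, and any real gap between the two mirror images could only come from configuration: the fact that compounds 2 and 4 differ only in the configuration as drawn The size of that gap cannot be read, and even a real separation of the pair cannot be claimed, because the value for compound 4 stops at the ceiling of the assay: the limit of > 10000 nM in this assay, at which 1 of the 4 values shown sits.

Going by these compounds, compound 1 and compound 3 are drawn without configuration, so it remains open whether the same inversion would act in the same direction on either of them. Also open, on these data alone, is how a nitrile or a longer chain on the shared core would read in each mirror-image form, and whether any such compound in the configuration of compound 4 would come off the limit and give a number that can be compared.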